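A few compounds are considered here, and "the series" means these few. Any claim that something is new, unique, unknown or untested is made for them only; others in the source may bear on it.

Compound 1 `CC(=O)Oc1ccccc1C(=O)O[C@H]1CO[C@H]2[C@@H]1OC[C@H]2OC(=O)c1snnc1C` is the shortest-lived of the three measured esters in an ADME assay on a cell-free system (plasma, Homo sapiens) for metabolic stability, with Plasma (Rattus norvegicus) as the target, read by HPLC, at pH 7.4; on this read-out higher numbers stand for a longer-lived compound and lower numbers for a shorter-lived compound: compound 1 gives 0.0065 h, compound 2 `CC(=O)Oc1ccccc1C(=O)O[C@H]1CO[C@H]2[C@@H]1OC[C@H]2OC(=O)c1cccc(O)c1` gives 0.015 h, and compound 3 `CC(=O)Oc1ccccc1C(=O)O[C@H]1CO[C@H]2[C@@H]1OC[C@H]2OC(=O)c1ccc(C)cc1` gives 0.0362 h. Compound 4 `COc1ccccc1C(=O)O[C@@H]1CO[C@H]2[C@@H]1OC[C@@H]2OC(=O)c1ccccc1OC(C)=O`, not yet measured, differs from compound 1 by 2-methoxyphenyl in place of 4-methyl-1,2,3-thiadiazol-5-yl on a carbonyl carbon. Going by the values given here, two measured steps bear on this change, both replacing the same five-membered aromatic ring with a six-membered aromatic ring of carbon only: a 2.3-fold higher number from compound 1 to compound 2 (0.36 log units; beyond the scatter) and a 5.6-fold higher number from compound 1 to compound 3 (0.75 log units; beyond the scatter). Both steps lengthened the half-life beyond the scatter, so a further increase is expected for compound 4, probably between those two steps in size, as a 4.3-fold higher number from compound 1 to compound 4 (0.63 log units; beyond the scatter). Compound 4 is therefore estimated at 0.028 h, within a range from 0.012 h to 0.065 h.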

Compound 4, half-life: 0.0165 h
Beside the measured number, compound 4's estimate is 1.7-fold (0.23 log units) above it; low and high end bracket the measured number.
By their numbers in this assay, from the lowest: compound 1; then compounds 2 and 4 (each within the scatter of the next); then compound 3.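

Replacing 4-methyl-1,2,3-thiadiazol-5-yl with 2-methoxyphenyl on a carbonyl carbon also lengthens the half-life in this assay (a 2.5-fold higher number from compound 1 to compound 4 (0.40 log units; beyond the scatter)), so all the carbon-only six-membered rings shown outlast the thiadiazole. The size of that gain differs with the group: 4-methylphenyl stays ahead of 2-methoxyphenyl (a 2.2-fold lower number from compound 3 to compound 4 (0.34 log units; beyond the scatter)), while 3-hydroxyphenyl and 2-methoxyphenyl cannot be told apart (a 1.1-fold higher number from compound 2 to compound 4 (0.04 log units; within the scatter)). No evidence is available to explain these differences. Still open, on these data alone, is how a phenyl ring carrying an amine or a carboxylic acid would behave at this position.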